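Notes on the step from compound 2 to compound 4

A few compounds are considered here, and "the series" means these few. Any claim that something is new, unique, unknown or untested is made for them only; others in the source may bear on it.

Measured so far:
compound 1, `CC1CCCc2c1[nH]c(=O)c(C#N)c2-c1cccn1C`: > 100000 nM
compound 2, `Cn1cccc1-c1cc(-c2cccs2)nc(N)c1C#N`: > 100000 nM
compound 3, `COc1ccc(-c2cc(-c3cccn3C)c(C#N)c(N)n2)cc1OC`: > 100000 nM

All three values come from a functional assay on NCI-H226 cells (Homo sapiens) for inhibition, read by sulforhodamine B assay, with a stated time of 48 h; a higher number here means a weaker inhibitor of growth, a lower number a stronger inhibitor of growth. For compound 1 the value > 100000 nM is a limit of the assay and not a number. For compound 2 the value > 100000 nM is likewise a limit. For compound 3 the value > 100000 nM is a limit as well. Going by the values given here, compound 2 therefore cannot be placed against compound 1 or compound 3: every value shown sits at the same limit, and no pair of the measured structures differs in one place, so no measured step is at hand. Among the compounds with values here, the only evidence is the limit of > 100000 nM in this assay, at which 3 of the 3 values shown sit.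

Compound 4, `Cn1cccc1-c1cc(-c2ccccc2)nc(N)c1C#N`, is the compound still to be measured in this assay. It differs from compound 2 in this way: phenyl in place of thiophen-2-yl on an aromatic carbon. Within the data shown here, nothing in the measured set says what this change does, and no compound has yet reached a number in this assay. The expectation is no step beyond the scatter, compound 4 being expected to give 100000 nM, within 30000 nM to 500000 nM. The estimated step is a number no higher from compound 2 to compound 4 (the limit leaves the size open), that is, flat, with a high chance that compound 4 also comes back only as a limit.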

Compound 4, concentration for 50% growth inhibition: > 100000 nM
Compound 4 was reported as a limit (the forecaster's own chance of this, stated with the estimate: 85%); the middle value lies on the limit itself.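

In this assay compound 4 gives > 100000 nM, which is a limit of the assay and not a number. Compound 2 also stands only at a limit, so no step can be read for phenyl in place of thiophen-2-yl. The compounds shown leave open which change on the shared core, if any, would give a measurable value, and the only evidence remains: the limit of > 100000 nM in this assay, at which 4 of the 4 values shown sit.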